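The compounds below may be only part of what the source reports. "The series", "measured", "known", "first", "only" and "open" are said of these compounds alone.

Compound 3 `CC[C@H](C)[C@H](N)CN(C(=O)[C@@H]1C[C@H]1c1cncnc1)c1ccc(-c2ccccc2)cc1` gives 19000 nM in a functional assay for agonist activity at G protein-coupled receptor 88 (Homo sapiens), read by HTRF and cAMP accumulation (a lower number here means that less compound is needed, a higher number that more compound is needed for the effect), the highest of the three numbers measured here. Compound 1 `CC[C@H](C)[C@H](N)CN(C(=O)[C@@H]1C[C@H]1c1cccc(OC)c1)c1ccc(-c2ccccc2)cc1` gives 3000 nM, and compound 2 `CC[C@H](C)[C@H](N)CN(C(=O)[C@@H]1C[C@H]1c1ccccn1)c1ccc(-c2ccccc2)cc1` gives 130 nM. The step of a 6.3-fold higher number from compound 1 to compound 3 (0.80 log units; beyond the scatter) was modest, while the step of a 150-fold higher number from compound 2 to compound 3 (2.16 log units; beyond the scatter) was large. Compound 4 `CC[C@H](C)[C@H](N)CN(C(=O)[C@@H]1C[C@H]1c1ncc(C)s1)c1ccc(-c2ccccc2)cc1` differs from compound 3 by 5-methyl-1,3-thiazol-2-yl in place of pyrimidin-5-yl on a saturated ring carbon. The measured steps that exchange the aromatic group on this saturated ring carbon bear on it: a 23-fold lower number from compound 1 to compound 2 (1.36 log units; beyond the scatter) and a 150-fold higher number from compound 2 to compound 3 (2.16 log units; beyond the scatter) show that such swaps move the number by large amounts, and compound 3 already stands at the high end of what has been seen. A large move toward a lower number is therefore expected for compound 4, though its size is uncertain; no five-membered ring appears among the measured compounds, so the expectation leans on the spread of the three numbers rather than on a close match. The step of a 24-fold lower number from compound 3 to compound 4 (1.38 log units; beyond the scatter) is the expected outcome. Compound 4 is estimated at 800 nM, with a range from 150 nM to 5000 nM.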

Compound 4, half-maximal effective concentration: 1300 nM
Compound 4: middle estimate off by 1.6-fold (0.21 log units), on the low side; measured number inside the range.
By their numbers in this assay, from the lowest: compound 2; then compound 4; then compound 1; then compound 3.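

In this assay a five-membered aromatic ring on this saturated ring carbon gives a 15-fold lower number from compound 3 to compound 4 (1.16 log units; beyond the scatter) even though the groups exchanged have the same counts of heavy atoms and hydrogen-bond acceptors, so these counts alone do not set the number here. The 5-methyl-1,3-thiazol-2-yl group does not match pyridin-2-yl, with a 10-fold higher number from compound 2 to compound 4 (1.00 log units; beyond the scatter) as the step, but it improves on 3-methoxyphenyl, with a 2.3-fold lower number from compound 1 to compound 4 (0.36 log units; beyond the scatter) as the step. A five-membered ring therefore fits within the range set by the six-membered groups, without giving the lowest number.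

On these data alone, how a 1,3-thiazol-2-yl group with no methyl, or with an ethyl chain or an amine in its place, would read remains open. No measurement shown bears on why these aromatic groups fall in this order.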